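The compounds below may be only part of what the source reports. "The series", "measured", "known", "first", "only" and "open" are said of these compounds alone.

Working notes on the series. In an ADME assay on HeLa cells (Homo sapiens) for cytotoxicity, read by LDH release, with a stated time of 24 h (a lower number here means a stronger inhibitor, a higher number a weaker inhibitor), compound 1 `CCCNCc1ccc2c(Br)cc(Br)c(O)c2n1` gives > 100000 nM, and this is a limit. Compound 2 `CCCCOCc1ccc2c(Br)cc(Br)c(O)c2n1` gives > 50000 nM, and this too is a limit, so compound 2 has no exact number to stand on. Among the measured compounds shown here, the only measured step is a step that the two limits leave unreadable from compound 1 to compound 2, which supplies no size to carry forward. Compound 3 `OCc1ccc2c(Br)cc(Br)c(O)c2n1` differs from compound 2 by one change, hydrogen in place of butyl on an oxygen on a saturated carbon, or butoxymethyl to hydroxymethyl. For the measured compounds named here, no measured step covers this exchange, so no shift beyond the scatter is expected in this assay, and no direction can be assigned. The estimated step is a step that the limit leaves unreadable from compound 2 to compound 3. For compound 3 the expected value is 60000 nM, with an estimated range of 15000 nM to 150000 nM, and a further limit rather than a number is likely.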

Compound 3, half-maximal inhibitory concentration: > 100000 nM
Compound 3 gave a limit, no number; the forecaster's own chance of this, stated with the estimate: 65%; middle value at least 1.6-fold (0.22 log units) away from the limit.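

In this assay compound 3 gives > 100000 nM, a limit. Among the compounds shown here, with compound 1, compound 2 and compound 3 all standing as limits, no step among them can be read. The compounds shown leave open whether exchanging these side chains shifts the read-out at all.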